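The source may report more compounds than this note shows. Statements on the series, on what has been measured and on what is new or still open speak of the compounds shown alone.

Measured so far:

Compound 1, `CC(C)n1cnc2c(N)ncnc21`, in an assay on CHO cells for displacement of a labelled ligand from adenosine receptor A1 (Homo sapiens) (on this read-out lower numbers stand for stronger inhibition and higher numbers for weaker inhibition), compound 1 gives 4300 nM.
Compound 2, `CC(C)n1cnc2ncnc(N)c21`, in this assay compound 2 gives 20000 nM.
Compound 3, `CC(C)Cn1cnc2c(N)ncnc21`, in this assay compound 3 gives > 100000 nM; this is a limit of the assay, not a number, as told by the limit of > 100000 nM in this assay, at which 1 of the 3 values shown sits.

Compound 2 holds the highest of the two numbers shown; the nearest is compound 1, whose number is lower, a gap beyond the usual scatter. Compound 4, `Nc1ncnc2ncn(CCO)c12`, has not yet been measured in this assay. It differs from compound 2 by 2-hydroxyethyl in place of isopropyl on an aromatic nitrogen.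

Within the data shown here, only one measured step touches the chain on the aromatic nitrogen: an at least 23-fold higher number from compound 1 to compound 3 (1.36 log units; beyond the scatter). That step shows a large weakening from a chain change at the same kind of place, though on the other arrangement of the shared core, and compound 2 already sits at a weak number. The step from compound 2 to compound 4 is therefore expected to be a moderate weakening, with a real chance of only a limit, a 2.0-fold higher number from compound 2 to compound 4 (0.30 log units; within the scatter). Compound 4 is estimated to give 40000 nM, with a range from 8000 nM to 200000 nM.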

Compound 4, inhibition constant: > 100000 nM
Compound 4 was reported as a limit (the forecaster's own chance of this, stated with the estimate: 45%); middle value at least 2.5-fold (0.39 log units) from the limit.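

In this assay, 2-hydroxyethyl in place of isopropyl on the aromatic nitrogen gives an at least 5.0-fold higher number from compound 2 to compound 4 (0.69 log units; beyond the scatter). The heavy-atom count of the chain stays at 3, so a change in its makeup alone, with an oxygen entering for a carbon, is enough to move the number beyond the scatter, and this holds on the arrangement of the shared core where the earlier chain step gave no information. Compound 4 is reported only as a limit of the assay, so the true size of this step stays unknown, because the value marks where the assay ends: the limit of > 100000 nM in this assay, at which 2 of the 4 values shown sit.

The compounds shown cannot separate the effect of the hydroxyl group from that of losing the branch in the chain. A straight propyl chain or a 2-aminoethyl chain on the same nitrogen would help tell these apart.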